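Compound 2 with every configuration drawn

The source may report more compounds than this note shows. Statements on the series, on what has been measured and on what is new or still open speak of the compounds shown alone.

- Compound 1 `CN1N=C(OC2c3cc(C#N)ccc3OC(C)(C)C2O)C2CC2C1=O` has the entries > 1 mg/kg; 0.047 mg/kg (2 entries) on record, and these entries do not come down to one single number
- Compound 2 `CN1N=C(OC2c3cc(C#N)ccc3OC(C)(C)C2(C)O)C2CC2C1=O` has the entry 0.0042 mg/kg on record

Among the compounds with values here, in a functional assay on the whole organism with Rattus norvegicus as the target (on this read-out higher numbers stand for an effect only at larger amounts of compound and lower numbers for an effect already at smaller amounts), compound 2 gives 0.0042 mg/kg as the only single number in this small set, and it stands lower than the numerical entry of compound 1.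

Compound 3 `CN1N=C(O[C@@H]2c3cc(C#N)ccc3OC(C)(C)[C@@]2(C)O)[C@@H]2C[C@@H]2C1=O` differs from compound 2 by one kind of change the two compounds have the same atoms and bonds; at least one stereo element is drawn with a configuration in one of them and without one in the other: 4 of 4 stereo elements differ; a stereocentre at a saturated ring carbon is drawn without a configuration in compound 2 and R in compound 3; a stereocentre at a saturated ring carbon is drawn without a configuration in compound 2 and S in compound 3; a stereocentre at a saturated ring carbon is drawn without a configuration in compound 2 and R in compound 3; a stereocentre at a saturated ring carbon is drawn without a configuration in compound 2 and S in compound 3 and so carries the same atoms and bonds, with every configuration drawn. Within the data shown here, no measured pair shows what such a change does. The expectation therefore starts from compound 2 at 0.0042 mg/kg and stays close to that number, leaning slightly lower should the drawn form be the one that carries the effect. In this assay the expected result is a 1.7-fold lower number from compound 2 to compound 3 (0.23 log units; within the scatter) and no step beyond the scatter is expected. For compound 3 the estimate is 0.0025 mg/kg with an expected range from 0.0007 mg/kg to 0.009 mg/kg as the likely span.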

Compound 3, dose for half-maximal effect: 0.0023 mg/kg
Beside the measured number, compound 3's estimate is 1.1-fold (0.04 log units) above it; the measured number falls inside the stated range.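

In this assay, drawing every stereocentre with a configuration gives a 1.8-fold lower number from compound 2 to compound 3 (0.26 log units; within the scatter), so the defined form stays level with the undefined drawing. Within the data shown here, this is the first sign that the effect at such small doses is retained by a single drawn arrangement at these saturated ring carbons, rather than being seen only for a drawing that leaves them open. How much any other arrangement contributes cannot be read, because the drawing of compound 2 does not say which forms it contains: the fact that one of compounds 2 and 3 is drawn with a defined configuration and the other without, at the place where they differ

From the compounds shown here alone, what the methyl that separates compound 1 from compound 2 contributes stays open, as the entries of compound 1 include a limit of the assay and come down to no single number: the several entries of compound 1 in this assay, > 1 mg/kg; 0.047 mg/kg (2 entries) Also open is how the other configurations at these stereocentres behave in this assay, and whether an ethyl group or a longer chain in place of that methyl would keep the effect at such small doses.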